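A few compounds are considered here, and "the series" means these few. Any claim that something is new, unique, unknown or untested is made for them only; others in the source may bear on it.

Measured so far:
compound 1 `CN(C)c1ccc(CN(Cc2cccc(-c3cc[nH]n3)c2)C(=O)Nc2c(F)cc(F)cc2F)cc1`, < 0.32 mg/kg;
compound 2 `O=C(Nc1c(F)cc(F)cc1F)N(Cc1ccc(F)cc1)Cc1cccc(-c2cc[nH]n2)c1`, < 0.32 mg/kg;
compound 3 `CSc1cc(C)nc(SC)c1NC(=O)N(Cc1ccc(N(C)C)cc1)Cc1cccc(-c2cc[nH]n2)c1`, < 0.1 mg/kg.

All three values in a functional assay on a cell-free system (plasma) with sterol O-acyltransferase, Soat (Rattus norvegicus) as the target (a higher number here means that more compound is needed for the effect, a lower number that less compound is needed), are limits of the assay rather than numbers. Compound 1 gives < 0.32 mg/kg, a limit. Compound 2 gives < 0.32 mg/kg, again a limit. Compound 3 gives < 0.1 mg/kg, also a limit. Hence the step that the two limits leave unreadable from compound 1 to compound 2, which is the change (fluoro in place of dimethylamino on an aromatic carbon), cannot be sized, and the same holds for the step that the two limits leave unreadable from compound 1 to compound 3, where the two cores differ by a group of 11 heavy atoms (8 carbon, 1 nitrogen, 2 sulfur; one six-membered aromatic ring with 1 hetero atom) in place of a group of 9 heavy atoms (6 carbon, 3 fluorine; one six-membered aromatic ring of carbon only), on an amide-type nitrogen. Two of the values sit at the limit of < 0.32 mg/kg in this assay, at which 2 of the 3 values shown sit, and one at the limit of < 0.1 mg/kg in this assay, at which 1 of the 3 values shown sits.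

Compound 4 `CSc1cc(C)nc(SC)c1NC(=O)N(Cc1ccc(F)cc1)Cc1cccc(-c2cc[nH]n2)c1` has not yet been measured. It differs from compound 3 by fluoro in place of dimethylamino on an aromatic carbon, the same change as that from compound 1 to compound 2, at the same place. As the earlier step could not be read, compound 4 is expected to stay close to compound 3, with an expected step of an at least 1.5-fold higher number from compound 3 to compound 4 (0.17 log units; that floor lies within the scatter). Compound 4 is estimated at 0.15 mg/kg, between 0.04 mg/kg and 0.5 mg/kg, and will most probably again be reported only as a limit.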

Compound 4, dose for half-maximal effect: < 0.1 mg/kg
Compound 4: a limit, no number (the forecaster's own chance of this, stated with the estimate: 80%); middle value at least 1.5-fold (0.17 log units) away from the limit.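

In this assay compound 4 gives < 0.1 mg/kg, a limit and not a number. Compound 2, compound 3 and compound 4 all stand as limits, so the steps to compound 4 from the other two cannot be read. The compounds shown leave open whether fluoro in place of dimethylamino, or the exchange on the amide-type nitrogen, changes the dose needed at all.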